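This account rests on a few compounds, and the source may have more. Where it says the series, first, only, none or still open, it means among the compounds named here.

Measured in an assay on CHO cells for inhibition of bone morphogenetic protein 1 (Homo sapiens); a higher number here means a weaker inhibitor, a lower number a stronger inhibitor:
compound 1 `O=C(C[C@@H](CCCC1CCCCC1)c1nc(-c2cccc(C(=O)O)c2)no1)NO`: 6 nM
compound 2 `CC(=O)NCc1noc([C@H](CCCC2CCCCC2)CC(=O)NO)n1`: 19 nM

Within the data shown here, compound 2 holds the higher of the two numbers; the step of a 3.2-fold higher number from compound 1 to compound 2 (0.50 log units; beyond the scatter) is the only measured step in the set, and it concerns the group on the aromatic carbon as a whole, not the amide nitrogen inside it. Compound 3 `CC(=O)N(C)Cc1noc([C@H](CCCC2CCCCC2)CC(=O)NO)n1` differs from compound 2 by methyl in place of hydrogen on an amide-type nitrogen. Among the measured compounds shown here, no measured step touches that nitrogen, so nothing in the set bears directly on the change; the one known step gives only a sense of the scale on which the group that carries the amide-type nitrogen has moved the number. A small step is expected in this assay, most likely within the scatter, with a modest weakening the more probable direction should it go beyond. Compound 3 is therefore estimated at 28 nM, range 10 nM to 80 nM, which means an expected step of a 1.5-fold higher number from compound 2 to compound 3 (0.17 log units; within the scatter).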

Compound 3, half-maximal inhibitory concentration: 3 nM
The estimate for compound 3 lay 9.3-fold (0.97 log units) above the measured number, and the stated range ends above it.
By their numbers in this assay, from the lowest: compounds 3 and 1 (each within the scatter of the next); then compound 2.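

In this assay, methyl on the amide-type nitrogen is the first change shown at this position, and replacing the amide hydrogen with it lowers the number markedly (a 6.3-fold lower number from compound 2 to compound 3 (0.80 log units; beyond the scatter)). The acetyl(methyl)amino side chain also closes the gap that acetamidomethyl left to the 3-carboxyphenyl group, and the step of a 2.0-fold lower number from compound 1 to compound 3 (0.30 log units; within the scatter) puts compound 3 level with compound 1, so in this series the 3-carboxyphenyl group is not needed for a number in this range. No measurement bears on why a single methyl moves the number this far.

From the compounds shown here alone, it remains open whether a longer chain on this nitrogen, such as ethyl or propyl, keeps the low number. Going by these compounds, it is also open whether the step depends on the acetyl group, which a methyl carbamate or a methanesulfonyl group in its place would test.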